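A few compounds are considered here, and "the series" means these few. Any claim that something is new, unique, unknown or untested is made for them only; others in the source may bear on it.

Of the compounds shown here, three share one core and have been tested in an assay on isolated protein for inhibition of histone deacetylase 8 (Homo sapiens), read by fluorescence, with a stated time of 10 min; on this read-out higher numbers stand for weaker inhibition and lower numbers for stronger inhibition. Compound 1 `Cc1ccc(-c2noc(CCCCCCC(=O)NO)n2)cc1` gives 5390 nM. Compound 2 `O=C(CCCCCCc1nc(-c2cccs2)no1)NO` gives 1920 nM. Compound 3 `Cc1ccc(-c2noc(CCCCCCC(=O)Nc3ccccc3N)n2)cc1` gives 8390 nM.

Compound 3 sits at the top end of these three numbers. Its nearest neighbour is compound 1: the step of a 1.6-fold higher number from compound 1 to compound 3 (0.19 log units; within the scatter) lies within the usual scatter, so the two cannot be told apart with confidence. Compound 2 sits clearly lower than compound 3, beyond the scatter.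

Compound 4 `Nc1ccccc1NC(=O)CCCCCCc1nc(-c2cccc([N+](=O)[O-])c2)no1` has not yet been measured. It differs from compound 3 in one place: 3-nitrophenyl in place of 4-methylphenyl on an aromatic carbon.

Within the data shown here, only one measured step bears on this kind of change, an exchange of the aryl group on that same ring carbon: a 2.8-fold lower number from compound 1 to compound 2 (0.45 log units; beyond the scatter), a modest lowering. Among the measured compounds shown here, no measured step introduces 3-nitrophenyl itself, so the direction for compound 4 rests on a single example and remains uncertain.

For compound 4, a small lowering is expected, about a 1.7-fold lower number from compound 3 to compound 4 (0.22 log units; within the scatter) in this assay, though a result within the scatter would not be surprising. The estimate for compound 4 in this assay is 5000 nM, with a likely range from 2000 nM to 12000 nM.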

Compound 4, half-maximal inhibitory concentration: > 10000 nM
Compound 4 gave a limit, no number; the forecaster's own chance of this, stated with the estimate: 5%; at least 2.0-fold (0.30 log units) between middle value and limit.
By their numbers in this assay, from the lowest: compound 2; then compounds 1 and 3 (each within the scatter of the next). At a limit, above all of these: compound 4.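

In this assay, among these compounds, exchanging 4-methylphenyl for 3-nitrophenyl on this ring carbon gives an at least 1.1-fold higher number from compound 3 to compound 4 (0.07 log units; that floor lies within the scatter), so no lowering appears here, while the only earlier aryl exchange at this carbon, with hydroxy rather than 2-aminophenyl on the amide nitrogen and thiophen-2-yl as the incoming group, gave a 2.8-fold lower number from compound 1 to compound 2 (0.45 log units; beyond the scatter). A change of aryl group at this carbon therefore does not lower the number in every case, although the floor of the new step alone cannot separate the two compounds, and compound 4 may lie close to compound 3 or far from it. Compound 4 gives a limit of the assay and not a number, so the true size of its step remains unknown: the limit of > 10000 nM in this assay, at which 1 of the 4 values shown sits.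

The compounds shown leave open whether 3-nitrophenyl would behave the same way with hydroxy on the amide nitrogen, and whether thiophen-2-yl would lower the number with 2-aminophenyl there. They also do not tell how an amine or a carboxylic acid in place of the nitro group, or a longer chain, would read.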